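Removing one benzyl from compound 2

The source may report more compounds than this note shows. Statements on the series, on what has been measured and on what is new or still open speak of the compounds shown alone.

For the measured compounds named here, in a functional assay on HOS cells (Homo sapiens) for antiproliferative activity, read by sulforhodamine B assay (on this read-out lower numbers stand for stronger inhibition of growth and higher numbers for weaker inhibition of growth), compound 2 (`O[C@@H]1[C@@H](OCc2ccccc2)[C@H](OCc2ccccc2)[C@@H](COCc2ccccc2)O[C@H]1Cc1ccccc1`) gives 29200 nM as the only true number so far. Compound 1 (`OCCC[C@@H]1O[C@H](COCc2ccccc2)[C@@H](OCc2ccccc2)[C@H](OCc2ccccc2)[C@H]1O`) gives > 50000 nM and this is a limit of the assay, not a number.

Going by the values given here, the one measured step (an at least 1.7-fold lower number from compound 1 to compound 2 (0.23 log units; that floor lies within the scatter)) put phenyl in place of 2-hydroxyethyl on a saturated chain carbon bound to a saturated ring carbon. Its size is known only as a floor, and it lies elsewhere on the molecule, so it bears on the next change only indirectly.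

Compound 3 (`OC[C@H]1O[C@@H](Cc2ccccc2)[C@H](O)[C@@H](OCc2ccccc2)[C@@H]1OCc1ccccc1`) differs from compound 2 as follows: hydrogen in place of benzyl on an oxygen on a saturated carbon. Here benzyloxy becomes hydroxy, and no measured step covers that place. Among the compounds with values here, the sole guide is the step to compound 2 (an at least 1.7-fold lower number from compound 1 to compound 2 (0.23 log units; that floor lies within the scatter)), in which a hydroxy-bearing chain left and a phenyl entered. The reverse kind of change here points weakly towards a higher number, so only a small move is expected, and it may stay within the scatter.

The expected step is a 1.4-fold higher number from compound 2 to compound 3 (0.16 log units; within the scatter) in this assay and a report at the limit is quite possible. Compound 3 is estimated at 42000 nM (range 15000 nM to 110000 nM) in this read-out.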

Compound 3, concentration for 50% growth inhibition: 31600 nM
Beside the measured number, compound 3's estimate is 1.3-fold (0.12 log units) above it; low and high end bracket the measured number.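

In this assay the change from benzyloxy to hydroxy on this oxygen reads as a 1.1-fold higher number from compound 2 to compound 3 (0.03 log units; within the scatter), so the two groups cannot be told apart at this place. Unlike the earlier step, which is known only as a floor, this step has a true number at both ends and gives the series its first measured size of change. A whole benzyl, with 7 heavy atoms and one six-membered aromatic ring, can leave this oxygen with no readable shift, so this benzyl is not shown to be needed for the growth inhibition of compound 2, at 29200 nM.

Still open, on these data alone, is whether a group other than benzyl or hydrogen on this oxygen, such as a methyl ether or a longer chain ending in an amine, would move the number beyond the scatter. Also open is what the remaining benzyloxy groups on the shared core contribute, and compound 1 stays a limit and not a number: the limit of > 50000 nM in this assay, at which 1 of the 3 values shown sits.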